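Chloro to methyl on the benzyl ether of compound 1

The compounds below may be only part of what the source reports. "The series", "measured", "known", "first", "only" and "open" are said of these compounds alone.

Measured in an assay on isolated protein for displacement of a labelled ligand from cathepsin S (Homo sapiens), read by fluorescence; a lower number here means tighter binding, a higher number weaker binding:
- compound 1 `CC(C)C[C@H](NC(=O)N1CCOCC1)C(=O)N[C@H](C#N)COCc1ccccc1Cl` gives 0.3 nM
- compound 2 `N#C[C@H](CCc1ccccc1)NC(=O)[C@@H](NC(=O)N1CCOCC1)C1CCCCC1` gives 5 nM

Among the compounds with values here, compound 1 holds the lowest of the two numbers; compound 2, its only neighbour, sits well above it, and the gap between the two is beyond the scatter. Within the data shown here, no pair of measured compounds differing in a single place is available, so the step to compound 3 has no direct precedent within this set.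

Compound 3 `Cc1ccccc1COC[C@@H](C#N)NC(=O)[C@H](CC(C)C)NC(=O)N1CCOCC1` differs from compound 1 in one place only: methyl in place of chloro on an aromatic carbon. Everything else in the molecule is retained.

With nothing counted as changing beyond the exchange of one halogen for one carbon, a small step is expected. The step of a 1.7-fold higher number from compound 1 to compound 3 (0.22 log units; within the scatter) is expected to fall within the usual scatter, in either direction. Compound 3 is therefore estimated at 0.5 nM, with a range from 0.15 nM to 2 nM.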

Compound 3, dissociation constant: 3 nM
Estimate against measurement, compound 3: 6.0-fold (0.78 log units) below; measured number outside the range, above it.
By their numbers in this assay, from the lowest: compound 1; then compounds 3 and 2 (each within the scatter of the next).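

In this assay, the exchange at this position is not neutral: the change gives a 10-fold higher number from compound 1 to compound 3 (1.00 log units; beyond the scatter), although one heavy atom replaces one heavy atom and no ring, hydrogen-bond donor, hydrogen-bond acceptor or net charge enters or leaves. Within the data shown here, this is the first single-place comparison, and it shows that the aromatic carbon ortho to a large group on the benzyl ether responds to the choice between chloro and methyl. No measurement on hand accounts for the size of this step.

From the compounds shown here alone, how fluoro, bromo or methoxy on this same carbon would compare with chloro and methyl remains open. Also open, going by these compounds, is whether the exchange of chloro for methyl gives a step of similar size when another part of the core of compound 1 is altered.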